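The source may report more compounds than this note shows. Statements on the series, on what has been measured and on what is new or still open speak of the compounds shown alone.

Measured so far:
- compound 1, `Nc1sc2c(c1-c1nc3ccccc3s1)CCCC2`: 163 ug/mL
- compound 2, `Nc1sc2c(c1-c1nc3cc(Cl)ccc3s1)CCC2`: 67.8 ug/mL
- compound 3, `Fc1ccc(/C=N/c2sc3c(c2-c2nc4ccccc4s2)CCC3)cc1`: 302 ug/mL

In an ADME assay on HepG2 cells (Homo sapiens) for cytotoxicity, read by MTT assay, with a stated time of 72 h (a higher number here means that more compound is tolerated, a lower number that less compound is tolerated), compound 1 stands second highest of the three numbers. Compound 3 sits nearest, within the scatter, while compound 2 lies furthest, beyond the scatter on the lower side.

Compound 4, `Clc1ccccc1/C=N/c1sc2c(c1-c1nc3ccccc3s1)CCCC2`, has not been measured in this assay. Relative to compound 1 the change is a group of 9 heavy atoms (7 carbon, 1 nitrogen, 1 chlorine; one six-membered aromatic ring of carbon only) in place of one nitrogen atom, on an aromatic carbon. Among the compounds with values here, no measured pair isolates this exact step. Compound 3 carries a related group on a differently sized shared core and gives 302 ug/mL. The expected step of a 1.5-fold higher number from compound 1 to compound 4 (0.19 log units; within the scatter) is therefore upward, though only at the edge of the scatter. Compound 4 is estimated at 250 ug/mL, with a range from 120 ug/mL to 500 ug/mL.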

Compound 4, half-maximal cytotoxic concentration: 370 ug/mL
The estimate for compound 4 lay 1.5-fold (0.17 log units) below the measured number; measured number inside the range.
By their numbers in this assay, from the lowest: compound 2; then compounds 1, 3 and 4 (each within the scatter of the next, the first and the last beyond it).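

In this assay, the group of 9 heavy atoms in place of the amino group, on the aromatic carbon next to the ring sulfur, gives a 2.3-fold higher number from compound 1 to compound 4 (0.36 log units; beyond the scatter). Within the data shown here, this is the first step that isolates this position, and it shows that the position accepts a group with a six-membered aromatic ring with no fall in the tolerated concentration. Nothing available explains the step.

Which part of the entering group carries the step remains open, whether the chlorine, the aromatic ring or the double bond. On these data alone, how a simple acetamide or a carboxylic acid would read at this carbon also remains open.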